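Defining one ring stereocentre: compound 1 to compound 4

The source may report more compounds than this note shows. Statements on the series, on what has been measured and on what is new or still open speak of the compounds shown alone.

Three compounds of the series have numbers in a functional assay on KB cells (Homo sapiens) for inhibition, with a stated time of 72 h; a higher number here means a weaker inhibitor, a lower number a stronger inhibitor. Compound 1 `CC(=O)O[C@@]12CO[C@@H]1C[C@H](O)[C@@](C)(C(=O)[C@H](O)C1=C(C)C3C[C@@](O)([C@H](C)OC(=O)CCCC/C=C/CCCCC(=O)N[C@@H](c4ccccc4)[C@@H](O)C(=O)O3)C1(C)C)C2` gives 8000 nM. Compound 2 `C=CCCCCC(=O)N[C@@H](c1ccccc1)[C@@H](O)C(=O)OC1C[C@@](O)([C@H](C)OC(=O)CCCCC=C)C(C)(C)C([C@@H](O)C(=O)[C@@]2(C)C[C@]3(OC(C)=O)CO[C@@H]3C[C@@H]2O)=C1C` gives 500 nM, and compound 3 `CCCCC(=O)N[C@@H](c1ccccc1)[C@@H](O)C(=O)OC1C[C@@](O)([C@H](C)OC(=O)CCCC)C(C)(C)C([C@@H](O)C(=O)[C@@]2(C)C[C@]3(OC(C)=O)CO[C@@H]3C[C@@H]2O)=C1C` gives 10000 nM. Among these three numbers compound 1 stands second highest; its nearest neighbour is compound 3, whose number lies within the scatter of repeat measurements, so the two cannot be ordered, while compound 2 sits beyond the scatter with a clearly lower number.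

Compound 4 `CC(=O)O[C@@]12CO[C@@H]1C[C@H](O)[C@@](C)(C(=O)[C@H](O)C1=C(C)[C@@H]3C[C@@](O)([C@H](C)OC(=O)CCCC/C=C/CCCCC(=O)N[C@@H](c4ccccc4)[C@@H](O)C(=O)O3)C1(C)C)C2` has not been measured. Its difference from compound 1 is the two compounds have the same atoms and bonds; at least one stereo element is drawn with a configuration in one of them and without one in the other: 1 of 11 stereo elements differ; a stereocentre at a saturated ring carbon is drawn without a configuration in compound 1 and S in compound 4. Nothing enters and nothing leaves: the connectivity is identical, and the sole distinction is one ring stereocentre drawn with a configuration in compound 4 and left undrawn in compound 1. Among the compounds with values here, no measured pair shows what fixing an undrawn configuration does, so the expectation rests on the identity of atoms and bonds alone. The expected step is no change at the digits printed from compound 1 to compound 4 (within the scatter), which is to say none beyond the scatter. Compound 4 is therefore estimated at 8000 nM, with a range from 3000 nM to 20000 nM.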

Compound 4, half-maximal inhibitory concentration: 14000 nM
The estimate for compound 4 lay 1.8-fold (0.24 log units) below the measured number, and the stated range covers the measured number.
By their numbers in this assay, from the lowest: compound 2; then compounds 1, 3 and 4 (each within the scatter of the next).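

In this assay, within the data shown here, the ring stereocentre provides the first step between two compounds that differ in one place, with a 1.8-fold higher number from compound 1 to compound 4 (0.24 log units; within the scatter). Drawing this saturated ring carbon as S therefore gives a number that cannot be told apart from that of the undrawn form, so the values for the undrawn compound and the S compound can be treated as one level for this scaffold at present. The step says nothing firm about the role of the configuration itself, because it sets a defined drawing against an undefined one: the fact that one of compounds 1 and 4 is drawn with a defined configuration and the other without, at the place where they differ

On these data alone, whether the R configuration at this ring carbon gives a number beyond the scatter from that of compound 4 stays open, and with it whether this position responds to configuration at all. Also open, as far as these compounds go, is how this assay responds when the long chain of compound 4 is replaced by a fully saturated chain or a longer chain, or when that chain carries an amine in place of its alkene.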